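This account rests on a few compounds, and the source may have more. Where it says the series, first, only, none or still open, it means among the compounds named here.

Measured so far: compound 1 `CCCC(CC)n1ccc2cc(/C(C)=C/C(=O)Nc3ccccc3OCCCC(=O)O)ccc21` gives 9.3 nM in an assay on Prostate gland for inhibition of steroid 5-alpha-reductase (Rattus norvegicus); on this read-out lower numbers stand for stronger inhibition and higher numbers for weaker inhibition; compound 2 `C/C(=C\C(=O)Nc1ccccc1OCCCC(=O)O)c1ccc2c(ccn2Cc2ccc(C)cc2)c1` gives 88 nM.

Compound 2 stands at the higher of the two numbers, with a 9.5-fold higher number from compound 1 to compound 2 (0.98 log units; beyond the scatter) separating it from compound 1. Compound 3 `COc1ccc(Cn2ccc3cc(/C(C)=C/C(=O)Nc4ccccc4OCCCC(=O)O)ccc32)cc1` differs from compound 2 by methoxy in place of methyl on an aromatic carbon. Within the data shown here, no measured step touches this position; the only step known concerns the group on the aromatic nitrogen, so it gives no guide for the benzyl substituent. Compound 3 is therefore expected to stay within the scatter of compound 2, a step of about a 1.1-fold lower number from compound 2 to compound 3 (0.04 log units; within the scatter), estimated at 80 nM with a range of 35 nM to 200 nM.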

Compound 3, half-maximal inhibitory concentration: 480 nM
Compound 3: the middle estimate sits 6.0-fold (0.78 log units) below what was measured, and the stated range ends below it.
By their numbers in this assay, from the lowest: compound 1; then compound 2; then compound 3.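

In this assay the substituent on the benzyl group is not a silent position: methoxy in place of methyl gives a 5.5-fold higher number from compound 2 to compound 3 (0.74 log units; beyond the scatter), a step beyond the scatter. Among these compounds, the two changes add up, so the full replacement of 1-ethylbutyl on the aromatic nitrogen by 4-methoxybenzyl gives a 52-fold higher number from compound 1 to compound 3 (1.71 log units; beyond the scatter), the largest step so far. Nothing on hand explains the methoxy step.

Open, from the compounds shown here alone, is where a hydroxyl, a fluorine or an amine at this place on the phenyl would fall relative to compound 2 and compound 3. Also open, going by these compounds, is whether alkyl chains other than 1-ethylbutyl on the aromatic nitrogen would stay near compound 1.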